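Swapping the Arm Ring: Compound 2 to Compound 4

This account rests on a few compounds, and the source may have more. Where it says the series, first, only, none or still open, it means among the compounds named here.

The shared core appears in compound 1 `O=c1c2ccccc2c(Nc2n[nH]c3ccccc23)nn1-c1ccccc1`; in a functional assay on HCT-116 cells (Homo sapiens) for cytotoxicity, read by CellTiter-Glo, with a stated time of 5 days (a lower number here means a stronger inhibitor, a higher number a weaker inhibitor), compound 1 gives "not determined" (no result reported). Among the measured compounds shown here, compound 2 `Cc1cc(Nc2nn(Cc3cccnc3)c(=O)c3ccccc23)n[nH]1` holds the only single number among the three: in this assay compound 2 gives 2900 nM. Compound 3 `CC(=O)Nc1ccc(Cn2nc(Nc3cc[nH]n3)c3ccccc3c2=O)cc1` gives only a limit of the assay, > 30000 nM in this assay. Compound 3 thus stands at the limit of > 30000 nM in this assay, at which 1 of the 3 values shown sits.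

Compound 4 `Cc1cc(Nc2nn(Cc3csc(C)n3)c(=O)c3ccccc23)n[nH]1` differs from compound 2 by 2-methyl-1,3-thiazol-4-yl in place of pyridin-3-yl on a saturated chain carbon bound to an aromatic nitrogen. For the measured compounds named here, no measured pair shows this change, and the available values offer no hint of its direction. The step of a 1.0-fold higher number from compound 2 to compound 4 (0.01 log units; within the scatter) in this assay is therefore expected to stay within the usual scatter. Compound 4 is estimated at 3000 nM in this assay, with a range from 1000 nM to 10000 nM.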

Compound 4, half-maximal inhibitory concentration: 4180 nM
Compound 4: the middle estimate sits 1.4-fold (0.14 log units) below what was measured, and the stated range covers the measured number.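

In this assay, replacing pyridin-3-yl with 2-methyl-1,3-thiazol-4-yl on a saturated chain carbon bound to an aromatic nitrogen gives a 1.4-fold higher number from compound 2 to compound 4 (0.16 log units; within the scatter). Among the compounds shown here, this is the first measured pair at this position, and it shows that a five-membered aromatic ring with 2 hetero atoms can stand in for the six-membered ring without a step beyond the scatter. Nothing measured here gives a cause for this step.

The compounds shown leave open what the methyl on the thiazole contributes by itself. They also leave open how a morpholine or a carboxylic acid at this position would read in this assay.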